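This account rests on a few compounds, and the source may have more. Where it says the series, first, only, none or still open, it means among the compounds named here.

Measured in a functional assay on the whole organism with Mus musculus as the target; a lower number here means that less compound is needed, a higher number that more compound is needed for the effect:
- Compound 1 `COc1cc2c(cc1OC)C(c1ccc(Br)cc1)=NNC(=O)C2`: 110 umol/kg
- Compound 2 `COc1cc2c(cc1OC)C(c1ccccc1)=NN(C)C(=S)C2`: 30.6 umol/kg

Compound 2 holds the lower of the two numbers, and compound 1 lies above it by more than the scatter. Compound 3 `COc1cc2c(cc1OC)C(c1ccc(N)cc1)=NN(C)C(=S)C2` is still unmeasured. It differs from compound 2 as phenyl to 4-aminophenyl, with amino in place of hydrogen on an aromatic carbon. Within the data shown here, no measured pair isolates this change, so the expectation is tentative. A moderate fall in this assay, beyond the scatter, is expected, and the estimated step is a 2.2-fold lower number from compound 2 to compound 3 (0.34 log units; beyond the scatter). For compound 3 the estimated value is 14 umol/kg, with an expected range of 5 umol/kg to 40 umol/kg.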

Compound 3, dose for half-maximal effect: 29.8 umol/kg
The estimate for compound 3 lay 2.1-fold (0.33 log units) below the measured number; low and high end bracket the measured number.
By their numbers in this assay, from the lowest: compounds 3 and 2 (each within the scatter of the next); then compound 1.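

In this assay, among these compounds, amino in place of hydrogen on the aromatic carbon para to a large group gives a 1.0-fold lower number from compound 2 to compound 3 (0.01 log units; within the scatter), the first reading of a single change at this position. Phenyl to 4-aminophenyl therefore leaves the number unchanged within the scatter, so this position accepts amino without a readable effect. No available data explain this outcome.

From the compounds shown here alone, whether a larger or acidic group here, such as acetamido or a carboxylic acid, would also leave the number unchanged remains open. The effect of bromo at this position cannot be read, since compound 1 differs from compound 2 in more than one place.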